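The source may report more compounds than this note shows. Statements on the series, on what has been measured and on what is new or still open speak of the compounds shown alone.

Measured so far in a functional assay on C6 cells (Rattus norvegicus) for cytotoxicity, read by MTT assay, with a stated time of 24 h; a lower number here means a stronger inhibitor, a higher number a weaker inhibitor:
compound 1 `CN(C)CCCN1CCN(CC(=O)Nc2ccc(-c3nc4ccccc4o3)cc2)CC1`: 42300 nM
compound 2 `CN(C)CCN1CCN(CC(=O)Nc2ccc(-c3nc4cc(Cl)ccc4o3)cc2)CC1`: 1030 nM
compound 3 `Cc1cc(-c2nc3cc(Cl)ccc3o2)ccc1NC(=O)CCl`: > 100000 nM (a limit, not a number)

In this assay compound 1 gives 42300 nM and compound 2 gives 1030 nM. For compound 3 the assay reports only > 100000 nM, which is a limit of the measurement and not a number (the limit of > 100000 nM in this assay, at which 1 of the 3 values shown sits). Compound 3 therefore stands at the weak end of the three, with no exact figure known.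

Compound 4 `Cc1cc(-c2nc3ccccc3o2)ccc1NC(=O)CCl` differs from compound 3 by hydrogen in place of chloro on an aromatic carbon. Going by the values given here, no measured pair shows this change on its own, so no direction is expected beyond the scatter, and compound 4 is expected to remain at the limit of this assay. Compound 4 is estimated at 100000 nM, in the range 40000 nM to 300000 nM. The expected step is a number no higher from compound 3 to compound 4 (the limit leaves the size open).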

Compound 4, half-maximal inhibitory concentration: 27200 nM
The estimate for compound 4 lay 3.7-fold (0.57 log units) above the measured number, outside the stated range (below it).
By their numbers in this assay, from the lowest: compound 2; then compounds 4 and 1 (each within the scatter of the next). At a limit, above all of these: compound 3.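

Hydrogen in place of chloro on this aromatic carbon gives, in this assay, an at least 3.6-fold lower number from compound 3 to compound 4 (0.56 log units; beyond the scatter), the first single change in the series that can be read. Here the chloro compound carries the higher number, so chloro at this place brings no gain with this chloroacetyl amide. The true size of the step stays open, since compound 3 has only a limit: the limit of > 100000 nM in this assay, at which 1 of the 4 values shown sits.

From the compounds shown here alone, whether the same change holds in the presence of the longer amine-bearing chain of compound 2 remains open. So does the outcome with fluoro, methoxy or an amine on this aromatic carbon.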